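A few compounds are considered here, and "the series" means these few. Any claim that something is new, unique, unknown or untested is made for them only; others in the source may bear on it.

This account follows a single change made to compound 3, whose structure is `O=C(Nc1cccc(F)c1)c1cc(=O)[nH]c2cc(-c3ccsc3)ccc12`. In a functional assay on KYSE-410 cells (Homo sapiens) for antiproliferative activity, read by MTT assay, with a stated time of 72 h (a higher number here means a weaker inhibitor, a lower number a stronger inhibitor), compound 3 gives 4300 nM. Two other compounds were examined in the same way. Compound 1, with the structure `COc1ccc(NC(=O)c2cc(=O)[nH]c3cc(Br)ccc23)cc1`, reaches only the limit of the assay, > 20000 nM. Compound 2, with the structure `COc1ccc2c(C(=O)Nc3cc(F)cc(F)c3)cc(=O)[nH]c2n1`, likewise stops at the limit, > 20000 nM. Among the three results, compound 3 thus holds the only actual number, while the other two sit at the limit of > 20000 nM in this assay, at which 2 of the 3 values shown sit, so nothing can be said about how far apart they really are.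

Compound 4, whose structure is `Cc1cc(-c2ccc3c(C(=O)Nc4cccc(F)c4)cc(=O)[nH]c3c2)c(C)cc1F`, has not yet been measured in this assay. It differs from compound 3 in one place: 4-fluoro-2,5-dimethylphenyl in place of thiophen-3-yl on an aromatic carbon. Among the compounds with values here, no measured pair in this set is separated by a change of this kind, so there is no direct precedent for how much the number should move or in which direction.

Within the data shown here, with only one numeric value to build on, the expected step is a 1.2-fold lower number from compound 3 to compound 4 (0.09 log units; within the scatter), a change no larger than the scatter of repeated measurements. Compound 4 is therefore estimated at 3500 nM, with a likely range from 800 nM to 15000 nM.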

Compound 4, half-maximal inhibitory concentration: > 20000 nM
Compound 4: a limit, no number (the forecaster's own chance of this, stated with the estimate: 15%); middle value at least 5.7-fold (0.75 log units) from the limit.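

Within the data shown here, replacing thiophen-3-yl with 4-fluoro-2,5-dimethylphenyl on this aromatic carbon gives the first step in the set that can be read, an at least 4.6-fold higher number from compound 3 to compound 4 (0.66 log units; beyond the scatter), and so shows that this position does not treat all aromatic rings alike in this assay. Since a higher number means a weaker inhibitor, the change from a five-membered ring containing sulfur to a substituted six-membered ring of carbon only costs activity, leaving compound 4 with no measurable value in this range. The step gives only the smallest possible loss, and the real gap could be much larger, because the reading for compound 4 stops at a limit: the limit of > 20000 nM in this assay, at which 3 of the 4 values shown sit.

This single change alters the ring size, removes the sulfur and adds fluorine and two methyl groups all at once, so the compounds shown cannot say which of these differences matters. Going by these compounds, it also stays open whether a plain phenyl ring, or a thiophene carrying a small amine, on the same carbon would keep the activity of compound 3 or lose it.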